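A few compounds are considered here, and "the series" means these few. Any claim that something is new, unique, unknown or untested is made for them only; others in the source may bear on it.

Compound 1 `COc1ccc(-c2c(-c3ccc(OC)cc3)n(Cc3ccccc3)c3ncn(CCCO)c(=N)c23)cc1` gives 0.36 h in an ADME assay on microsomes from liver (Mus musculus, strain CD1) for metabolic stability, read by LC-MS, using NADPH, with a stated time of 60 min; a lower number here means that the compound disappears faster, a higher number that the compound lasts longer. Compound 2 `COc1ccc(Cn2c(-c3ccccc3)c(-c3ccccc3)c3c(=N)n(CCO)cnc32)cc1` gives 0.518 h. Compound 3 `COc1ccc(-c2c(-c3ccc(OC)cc3)n(Cc3ccccc3)c3ncn([C@@H]4CCCC[C@H]4O)c(=N)c23)cc1` gives 0.487 h.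

Compound 3 stands among the three half-lives with both other compounds inside the usual scatter of it, so these three numbers do not separate from one another. Compound 4 `COc1ccc(-c2c(-c3ccc(OC)cc3)n(Cc3ccccc3)c3ncn(C4CCOCC4)c(=N)c23)cc1` differs from compound 3 by oxan-4-yl in place of 2-hydroxycyclohexyl on an aromatic nitrogen. Within the data shown here, the only measured step at that position, a 1.4-fold higher number from compound 1 to compound 3 (0.13 log units; within the scatter), stayed within the scatter, and no measured pair exchanges 2-hydroxycyclohexyl for oxan-4-yl. Nothing in the three measured compounds therefore points to a step beyond the scatter in this assay. Compound 4 is accordingly expected to give about 0.45 h, somewhere between 0.22 h and 0.95 h, which would mean a 1.1-fold lower number from compound 3 to compound 4 (0.03 log units; within the scatter).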

Compound 4, half-life: 0.978 h
The estimate for compound 4 lay 2.2-fold (0.34 log units) below the measured number, and the stated range ends below it.
By their numbers in this assay, from the lowest: compounds 1, 3, 2 and 4 (each within the scatter of the next, the first and the last beyond it).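

In this assay, oxan-4-yl in place of 2-hydroxycyclohexyl gives a 2.0-fold higher number from compound 3 to compound 4 (0.30 log units; within the scatter), while oxan-4-yl in place of 3-hydroxypropyl gives a 2.7-fold higher number from compound 1 to compound 4 (0.43 log units; beyond the scatter). Among these compounds, this second step is the first at this aromatic nitrogen to pass beyond the scatter, so the position can move the half-life, though modestly so far. Nothing available explains why this step is larger than the earlier one. The compounds shown leave open how an amine or a carboxylic acid at this nitrogen would compare with oxan-4-yl, and whether plain cyclohexyl would match it.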